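A few compounds are considered here, and "the series" means these few. Any claim that something is new, unique, unknown or untested is made for them only; others in the source may bear on it.

Measured so far:
compound 1, `Nc1ccccc1-c1nnc[nH]1` — 2000 nM
compound 2, `Nc1ccc(Cl)cc1-c1nnc[nH]1` — 35 nM
compound 3, `Oc1ccccc1-c1nnn[nH]1` — 700000 nM

In an assay on cells for inhibition of Indoleamine 2,3-dioxygenase 1 (Homo sapiens), read by HPLC, with a stated time of 20 min (on this read-out lower numbers stand for stronger inhibition and higher numbers for weaker inhibition), compound 1 gives 2000 nM, while compound 2 gives 35 nM. Compound 2 differs from compound 1 only by chloro in place of hydrogen on an aromatic carbon, and this single change produced a 57-fold lower number from compound 1 to compound 2 (1.76 log units; beyond the scatter).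

Compound 3 carries a different core; the difference between the core of compound 3 and the core of compound 1 is not broken down here. In this assay compound 3 gives 700000 nM, the highest number of the three, and its gaps to compound 1 and to compound 2 both lie beyond the scatter.

Compound 4, `Oc1ccc(Cl)cc1-c1nnn[nH]1`, has not yet been measured. It stands to compound 3 as compound 2 stands to compound 1: the change is chloro in place of hydrogen on an aromatic carbon. The two changes are of the same kind but not identical in their surroundings: in compound 4 the chloro sits para to a hydroxy group, in compound 2 para to an amino group.

For compound 4 in this assay a step of an 18-fold lower number from compound 3 to compound 4 (1.24 log units; beyond the scatter) is expected, resting on the precedent of a 57-fold lower number from compound 1 to compound 2 (1.76 log units; beyond the scatter) in compound 2 and tempered by the different core and the hydroxy in place of the amino. Compound 4 is therefore estimated at 40000 nM, most plausibly between 8000 nM and 250000 nM.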

Compound 4, half-maximal inhibitory concentration: 16000 nM
Beside the measured number, compound 4's estimate is 2.5-fold (0.40 log units) above it; the range from low to high includes it.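

In this assay, chloro in place of hydrogen on an aromatic carbon, here para to a hydroxy group, gives a 44-fold lower number from compound 3 to compound 4 (1.64 log units; beyond the scatter), and the size of the step carries over from one core to the other: the same change on two cores in this assay, a 57-fold lower number (1.76 log units; beyond the scatter) from compound 1 to compound 2 and a 44-fold lower number (1.64 log units; beyond the scatter) from compound 3 to compound 4, 1.3-fold (0.12 log units) apart, within the scatter of two such steps

For this series, the change can therefore be treated as transferable between these two cores, with a step of similar size expected on each, but that reading rests on just two matched pairs and does not extend to any further core. The data do not show why the step holds, and compound 1 and compound 3 differ in more than one place, so the separate contributions of the core and of the hydroxy group in place of the amino group cannot be read from them.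

The compounds shown leave open whether the step belongs to chloro alone or would also appear with fluoro, bromo, methyl or methoxy on the same carbon. Also open, going by these compounds, is how chloro behaves on another carbon of the six-membered aromatic ring, and whether the step survives when a carboxylic acid stands in place of the hydroxy group.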